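From pyridin-4-yl to phenyl in an antiproliferative series

The source may hold more compounds than are shown below. What is called first, only, known or untested is meant among the compounds shown, and "the series" means these compounds.

- Compound 1 (`CCN(c1ccc(C#N)c(Cl)c1)c1cc(-c2ccncc2)ccc1C`): 1030 nM
- Compound 2 (`N#Cc1ccc(N2CCc3cc(-c4cccnc4)ccc32)cc1C(F)(F)F`): "not determined" (no result reported)

Within the data shown here, in a functional assay on CWR22R cells (Homo sapiens) for antiproliferative activity, read by CCK-8 assay, with a stated time of 6 days (on this read-out higher numbers stand for weaker inhibition and lower numbers for stronger inhibition), compound 1 holds the only number (1030 nM), so it cannot yet be ranked against anything. Compound 2 has no numerical result ("not determined" (no result reported)). Compound 3 (`CCN(c1ccc(C#N)c(Cl)c1)c1cc(-c2ccccc2)ccc1C`) differs from compound 1 by one change (phenyl in place of pyridin-4-yl on an aromatic carbon): phenyl in place of pyridin-4-yl on an aromatic carbon. Among the measured compounds shown here, no measured step offers a guide, so only a small shift toward weaker inhibition, possibly within the scatter, is expected, with an estimated step (a 1.4-fold higher number from compound 1 to compound 3 (0.13 log units; within the scatter)). Compound 3 is expected to give about 1400 nM (estimated range 450 nM to 4000 nM).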

Compound 3, half-maximal inhibitory concentration: > 30000 nM
Compound 3: only a limit was reported; the forecaster's own chance of this, stated with the estimate: 8%; middle value at least 21-fold (1.33 log units) away from the limit.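

In this assay, the change from pyridin-4-yl to phenyl gives an at least 29-fold higher number from compound 1 to compound 3 (1.46 log units; beyond the scatter), so this aromatic carbon is sensitive to the exchange of one ring nitrogen for carbon, with the heavy-atom count unchanged. The result for compound 3 is a limit, not a number, so the full size of the step stays unknown: the limit of > 30000 nM in this assay, at which 1 of the 3 values shown sits.

The compounds shown leave open whether the ring nitrogen itself is what matters on this carbon. They also do not tell how an amine or a carboxylic acid would behave there.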